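The compounds below may be only part of what the source reports. "The series", "measured", "known", "first", "only" and "open" are said of these compounds alone.

Measured so far in a functional assay on JeKo-1 cells (Homo sapiens) for inhibition, read by luminescence and CellTiter-Glo, with a stated time of 72 h; on this read-out higher numbers stand for weaker inhibition and lower numbers for stronger inhibition:
Compound 1 `C=CC(=O)Nc1ccc(Cn2nc(-c3ccc(Oc4ccccc4)cc3)cc2C(=O)O)cc1`: compound 1 gives > 60000 nM, which is a limit of this assay rather than a number.
Compound 2 `O=C(CCl)Nc1cccc(Cn2nc(-c3ccc(Oc4ccccc4)cc3)cc2CO)c1`: compound 2 gives 400 nM.

Within the data shown here, compound 2 therefore holds the only actual number in this assay; the other value is the limit of > 60000 nM in this assay, at which 1 of the 2 values shown sits. Among the measured compounds shown here, no measured step between the two can be drawn, since compound 1 also carries a different amide and a different attachment of that amide, so the two values show only that compound 2 inhibits and compound 1 did not reach a number.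

Compound 3 `O=C(CCl)Nc1cccc(Cn2nc(-c3ccc(Oc4ccccc4)cc3)cc2C(=O)O)c1` is compound 2 with carboxy in place of hydroxymethyl on an aromatic carbon. For the measured compounds named here, the one carboxy compound measured, compound 1, sat at the limit of this assay, but it differs from compound 3 in more than one place, so that comparison is loose. The expected step is a 13-fold higher number from compound 2 to compound 3 (1.10 log units; beyond the scatter), a weakening beyond the scatter. Compound 3 is estimated at 5000 nM, in the range 800 nM to 60000 nM, with a fair chance that only a limit is reported.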

Compound 3, half-maximal inhibitory concentration: 6300 nM
Compound 3: the middle estimate sits 1.3-fold (0.10 log units) below what was measured; low and high end bracket the measured number.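

Carboxy in place of hydroxymethyl on an aromatic carbon gives a 16-fold higher number from compound 2 to compound 3 (1.20 log units; beyond the scatter) and is the first change in the series read in one place, so this position is sensitive to the swap, although compound 3 still gives a real number. Carboxy alone therefore does not take a compound to a limit, and compound 1 stays the only limit rather than a number: the limit of > 60000 nM in this assay, at which 1 of the 3 values shown sits. Placing 3-(((chloromethyl)carbonyl)amino)phenyl for 4-((vinylcarbonyl)amino)phenyl on the saturated chain carbon gives an at least 9.5-fold lower number from compound 1 to compound 3 (0.97 log units; beyond the scatter) and shows that, with carboxy held fixed, this group also matters.

That swap changes the amide and its attachment together, so the two remain unseparated. On these data alone, whether a methyl ester, a primary amide or an aminomethyl at the aromatic carbon would sit nearer compound 2 or compound 3 stays open.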